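A Hydroxypropyl Amide in Place of a Cyclopentyl Amide

A few compounds are considered here, and "the series" means these few. Any claim that something is new, unique, unknown or untested is made for them only; others in the source may bear on it.

Three compounds have been measured in an assay on HEK293 cells for displacement of a labelled ligand from adenosine receptor A2b (Homo sapiens), read by scintillation counting, with a stated time of 30 min, tested at 10 uM; on this read-out lower numbers stand for less inhibition and higher numbers for more inhibition at the one concentration tested (going by the name of the read-out):
compound 1, `O=C(NC1CCCC1)c1cc2ccccc2oc1=O`, gives 18%;
compound 2, `COc1cccc2cc(C(=O)NCCO)c(=N)oc12`, gives 65%;
compound 3, `COc1cccc2cc(C(=O)Nc3c(C#N)ncn3-c3ccccc3)c(=N)oc12`, gives 9%.

Compound 1 stands second highest of the three numbers. Its nearest neighbour is compound 3, whose number is lower by an amount within the usual scatter, so the two cannot be ordered. Compound 2 stands furthest away, higher by an amount beyond the scatter. Compound 2 differs from compound 1 in more than one place, so its higher number cannot be tied to any single change.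

Compound 4, `O=C(NCCCO)c1cc2ccccc2oc1=O`, has not yet been measured in this assay. It differs from compound 1 in one place: 3-hydroxypropyl in place of cyclopentyl on an amide-type nitrogen. Among the measured compounds, the only one carrying a hydroxyalkyl group on the amide-type nitrogen is compound 2, and its core is not that of compound 1, so no step between measured compounds shows what this change alone does.

The step from compound 1 to compound 4 in this assay is expected to be a modest rise, a number 12 percentage points higher from compound 1 to compound 4 (beyond the scatter), at the edge of the scatter rather than well beyond it. Compound 4 is estimated at 30%, with a range from 8% to 58%.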

Compound 4, a percentage reported as inhibition, at one concentration (the size of the read-out at that concentration, not a potency): 19%
Compound 4: middle estimate off by 11 percentage points, on the high side, within the range that was stated.
By their numbers in this assay, from the lowest: compounds 3, 1 and 4 (each within the scatter of the next); then compound 2.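

In this assay the replacement of cyclopentyl by 3-hydroxypropyl on the amide-type nitrogen gives a number 1 percentage points higher from compound 1 to compound 4 (within the scatter) and is the only step shown between measured compounds that differ in one place, so this change can now be read alone. On the core of compound 1, the five-membered carbon ring can be exchanged for an open chain carrying 1 hydrogen-bond donor and 1 hydrogen-bond acceptor, where cyclopentyl has neither, with no shift that can be told apart from the usual scatter of repeated measurements. At the one concentration tested, this read-out therefore does not separate these two groups at this position.

The compounds shown leave open whether a primary amine or a carboxylic acid at the end of the chain, a longer chain, or a phenyl group on the same nitrogen would give a number beyond the scatter from that of compound 1. They also leave open whether the same exchange of cyclopentyl for 3-hydroxypropyl would give so small a step on any other core.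

Nothing among the data shown offers an explanation for this result.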